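From furan-3-yl to thiophen-3-yl on a shared core

The source may report more compounds than this note shows. Statements on the series, on what has been measured and on what is new or still open speak of the compounds shown alone.

In an ADME assay on BJ cells (Homo sapiens), read by MTT assay, with a stated time of 72 h (a higher number here means a weaker inhibitor, a lower number a stronger inhibitor), compound 3 `CN(C)c1ncnc2c1c(-c1ccoc1)cn2[C@@H]1O[C@H](CO)[C@@H](O)[C@H]1O` gives 99200 nM. Compound 1 `CSc1ncnc2c1c(-c1ccsc1)cn2[C@@H]1O[C@H](CO)[C@@H](O)[C@H]1O` gives 95800 nM, which lies within the scatter of the value for compound 3. Compound 2 `CNc1ncnc2c1c(-c1ccsc1)cn2[C@@H]1O[C@H](CO)[C@@H](O)[C@H]1O` reads > 100000 nM, which is a limit of the assay and not a number. Compound 4 `CN(C)c1ncnc2c1c(-c1ccsc1)cn2[C@@H]1O[C@H](CO)[C@@H](O)[C@H]1O` carries thiophen-3-yl in place of furan-3-yl on an aromatic carbon. Among the compounds with values here, no measured step makes this swap. The only one available, an at least 1.0-fold higher number from compound 1 to compound 2 (0.01 log units; that floor lies within the scatter), changes a different group and leaves thiophen-3-yl untouched. No step beyond the scatter is therefore expected, and the estimated move is a 1.0-fold lower number from compound 3 to compound 4 (0.02 log units; within the scatter). Compound 4 is expected at 95000 nM, with an estimated range from 50000 nM to 150000 nM.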

Compound 4, half-maximal inhibitory concentration: > 100000 nM
Compound 4 gave a limit, no number; the forecaster's own chance of this, stated with the estimate: 45%; middle value at least 1.0-fold (0.02 log units) away from the limit.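

Compound 4 reads > 100000 nM, which is a limit of the assay and not a number. So thiophen-3-yl in place of furan-3-yl on an aromatic carbon gives a number no lower from compound 3 to compound 4 (the limit leaves the size open), the step from compound 2 cannot be read, and dimethylamino in place of methylsulfanyl gives an at least 1.0-fold higher number from compound 1 to compound 4 (0.01 log units; that floor lies within the scatter). The readings in this series include a shared limit: the limit of > 100000 nM in this assay, at which 2 of the 4 values shown sit.

As far as these compounds go, it remains open whether a phenyl ring or a carboxylic acid in place of thiophen-3-yl would give a clearly lower number in this assay.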